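Does Trifluoromethyl Wake an Inactive Compound?

The compounds below may be only part of what the source reports. "The series", "measured", "known", "first", "only" and "open" are said of these compounds alone.

In a functional assay on MCF7 cells (Homo sapiens) for antiproliferative activity, with a stated time of 96 h (on this read-out lower numbers stand for stronger inhibition and higher numbers for weaker inhibition), compound 1 `Cc1cc(=O)oc2cc(OCC(=O)c3ccc4c(c3)OCCCO4)ccc12` gives only a limit, > 100000 nM, and not a number. The two other compounds tested offer little more. Compound 2 `O=C(COc1ccc2c(C(F)(F)F)cc(=O)oc2c1)c1ccccc1C(F)(F)F` is reported as "not active" (no number reported), and compound 3 `COc1ccc(C(=O)COc2ccc3c(C(F)(F)F)cc(=O)oc3c2)cc1` is reported as "not active" (no number reported). Neither has a number, and both carry a trifluoromethyl group.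

Compound 4 `O=C(COc1ccc2c(C(F)(F)F)cc(=O)oc2c1)c1ccc2c(c1)OCCCO2` keeps the rest of compound 1 but has trifluoromethyl in place of methyl on an aromatic carbon, opposite the ring oxygen (trifluoromethyl in place of methyl on an aromatic carbon). Within the data shown here, no measured pair of compounds shows what this exchange does in this assay, so any forecast is loose. With compound 2 at "not active" (no number reported) and compound 3 at "not active" (no number reported), strong inhibition seems unlikely, and only a modest move towards lower numbers is expected, if any. The estimated change is an at least 1.6-fold lower number from compound 1 to compound 4 (0.22 log units; that floor lies within the scatter), and the assay may again report only a limit. For compound 4, the expected value is 60000 nM, with an estimated range from 8000 nM to 150000 nM.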

Compound 4, half-maximal inhibitory concentration: "not active" (no number reported)
The entry for compound 4 holds no number; the estimate stays without a comparison.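

Compound 1 gives only a limit. Among these compounds, compound 4 is reported as not active, with no number, so no step from compound 1 to compound 4 can be read. On these data alone, whether trifluoromethyl in place of methyl changes the result in this assay at all stays open.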